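The compounds below may be only part of what the source reports. "The series", "measured", "known", "first", "only" and "open" are said of these compounds alone.

Compound 1, `CCCCCCCCCCc1cn(C[C@H](O)[C@H]2OC(=O)C(OCc3ccccc3)=C2OCc2ccccc2)nn1`, in an ADME assay on HFF cells (Homo sapiens) for cytotoxicity, read by MTT assay, with a stated time of 72 h (on this read-out higher numbers stand for weaker inhibition and lower numbers for stronger inhibition), gives > 100000 nM, which is a limit of the assay and not a number.
Compound 2, `O=C1O[C@H]([C@@H](O)Cn2cc(CNS(=O)(=O)c3ccc(Cl)cc3)nn2)C(OCc2ccccc2)=C1OCc1ccccc1`, in this assay gives 20 nM.
Compound 3, `Cc1ccc(S(=O)(=O)NCc2cn(C[C@H](O)[C@H]3OC(=O)C(OCc4ccccc4)=C3OCc3ccccc3)nn2)cc1`, in this assay gives 50 nM.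

For the measured compounds named here, compound 3 stands highest of the two numbers so far, separated from its nearest neighbour by a 2.5-fold higher number from compound 2 to compound 3 (0.40 log units; beyond the scatter); the third value is only (the limit of > 100000 nM in this assay, at which 1 of the 3 values shown sits). The shared core is the same throughout; what varies is the group hanging from the triazole methylene. Swapping the nonyl chain for an arylsulfonylamino group brought an at least 5000-fold lower number from compound 1 to compound 2 (3.69 log units; beyond the scatter) and an at least 2000-fold lower number from compound 1 to compound 3 (3.30 log units; beyond the scatter), both large, while the difference between the two aryl sulfonyl groups, a methyl against a chloro, gave only the modest 2.5-fold higher number from compound 2 to compound 3 (0.40 log units; beyond the scatter).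

Compound 4, `O=C1O[C@H]([C@@H](O)Cn2cc(CNS(=O)(=O)c3ccc(Cl)cc3F)nn2)C(OCc2ccccc2)=C1OCc1ccccc1`, has not yet been measured. It differs from compound 3 by 4-chloro-2-fluorophenyl in place of 4-methylphenyl on a sulfonyl sulfur. Going by the values given here, only the step of a 2.5-fold higher number from compound 2 to compound 3 (0.40 log units; beyond the scatter) bears directly on this change, since it too replaced the methyl with a chloro; the added fluorine has no counterpart among the measured compounds. A modest move toward lower numbers, of roughly the size seen there, is therefore expected, and the step of a 2.5-fold lower number from compound 3 to compound 4 (0.40 log units; beyond the scatter) is estimated accordingly. For compound 4 the expected value in this assay is 20 nM, with a range of 8 nM to 50 nM.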

Compound 4, half-maximal inhibitory concentration: 20 nM
Beside the measured number, compound 4's estimate shows no gap at the digits printed, within the range that was stated.
By their numbers in this assay, from the lowest: compounds 2 and 4 (each within the scatter of the next); then compound 3. At a limit, above all of these: compound 1.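

In this assay, for the compounds shown here, the added fluoro can be judged on its own for the first time, and compounds 2 and 4 cannot be told apart: no change at the digits printed from compound 2 to compound 4 (within the scatter). The full swap of 4-methylphenyl for 4-chloro-2-fluorophenyl, a 2.5-fold lower number from compound 3 to compound 4 (0.40 log units; beyond the scatter), therefore reads the same as the swap of methyl for chloro alone, a 2.5-fold higher number from compound 2 to compound 3 (0.40 log units; beyond the scatter), so at this position the fluoro adds no visible shift to what the chloro compound already shows. Compound 1 remains a limit and not a number, so the step to this third arylsulfonylamino compound, an at least 5000-fold lower number from compound 1 to compound 4 (3.69 log units; beyond the scatter), gives only a minimum size: the limit of > 100000 nM in this assay, at which 1 of the 4 values shown sits.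

The compounds shown leave open whether a bromo or methoxy group on the same aromatic ring, or a plain phenyl ring with neither chloro nor methyl, would give a different number. They also leave open whether the sulfonyl is needed at all, since neither a carbonyl amide nor a free amine in place of the sulfonylamino group appears among them.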